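A few compounds are considered here, and "the series" means these few. Any claim that something is new, unique, unknown or untested is made for them only; others in the source may bear on it.

Compound 1 `COc1ncc(-c2ccc3nc(NC(=O)NCCN(C)C)sc3c2)cc1NS(=O)(=O)c1ccc(F)cc1` — in a functional assay on HCT-116 cells (Homo sapiens) for antiproliferative activity, read by MTT assay, with a stated time of 72 h (a lower number here means a stronger inhibitor, a higher number a weaker inhibitor), compound 1 gives 240 nM.
Compound 2 `CCOC(=O)CNc1nc2ccc(-c3cnc(OC)c(NS(=O)(=O)c4ccc(F)cc4)c3)cc2s1` — in this assay compound 2 reaches only the limit > 20000 nM.

Compound 2 therefore stands at the assay limit, (the limit of > 20000 nM in this assay, at which 1 of the 2 values shown sits), so only a range is known for it, and it is the weaker of the two by the step of an at least 83-fold higher number from compound 1 to compound 2 (1.92 log units; beyond the scatter).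

Compound 3 `COc1ncc(-c2ccc3nc(NC(=O)NCCN4CCN(C)CC4)sc3c2)cc1NS(=O)(=O)c1ccc(F)cc1` differs from compound 2 as (2-(4-methylpiperazin-1-yl)ethyl)carbamoyl in place of (ethoxycarbonyl)methyl on a nitrogen on an aromatic ring. This change returns to a carbamoyl-bearing nitrogen of the kind seen in compound 1, with a longer amine-containing chain. Among the compounds with values here, the only measured step that bears on it is an at least 83-fold higher number from compound 1 to compound 2 (1.92 log units; beyond the scatter), which ran the other way and was large. The step of an at least 66-fold lower number from compound 2 to compound 3 (1.82 log units; beyond the scatter) is thus expected to be large and downward in this assay. Compound 3 is estimated at 300 nM, with a range of 90 nM to 1500 nM.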

Compound 3, half-maximal inhibitory concentration: 540 nM
Beside the measured number, compound 3's estimate is 1.8-fold (0.26 log units) below it, and the stated range covers the measured number.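

Compound 2 is held at a limit of the assay, not at a number: the limit of > 20000 nM in this assay, at which 1 of the 3 values shown sits. With that reservation, in this assay the (2-(4-methylpiperazin-1-yl)ethyl)carbamoyl group on the nitrogen on an aromatic ring brings activity back, with an at least 37-fold lower number from compound 2 to compound 3 (1.56 log units; beyond the scatter), so the activity of this series is not tied to the dimethylamino end of compound 1. Exchanging the chain end itself matters far less, as 4-methylpiperazin-1-yl in place of dimethylamino gives a 2.3-fold higher number from compound 1 to compound 3 (0.35 log units; beyond the scatter), a modest step next to the large loss seen with (ethoxycarbonyl)methyl.

As far as these compounds go, what stays open is whether the carbamoyl group or the amine at the end of its chain carries the activity. A carbamoyl chain ending in a hydroxyl group instead of an amine would separate the two, and a longer chain would test the spacing.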